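The source may report more compounds than this note shows. Statements on the series, on what has been measured and on what is new or still open speak of the compounds shown alone.

Measured so far in a functional assay on HCT-116 cells (Homo sapiens) for cytotoxicity, read by MTT assay, with a stated time of 48 h; on this read-out higher numbers stand for weaker inhibition and lower numbers for stronger inhibition:
Compound 1 `Cc1nc2c3ccccc3ccc2c2nc3c(ccc4ccccc43)c(-c3cccc([N+](=O)[O-])c3)c12` gives 13200 nM.
Compound 2 `Cc1nc2c3ccccc3ccc2c2nc3c(ccc4ccccc43)c(-c3ccccc3)c12` reaches only the assay limit, > 80000 nM.
Compound 3 `Cc1nc2c3ccccc3ccc2c2nc3c(ccc4ccccc43)c(-c3ccccc3N)c12` gives 4760 nM.

Compound 3 thus holds the lowest of the two numbers, with compound 1 nearest: a 2.8-fold lower number from compound 1 to compound 3 (0.44 log units; beyond the scatter). Compound 4 `Cc1nc2c3ccccc3ccc2c2nc3c(ccc4ccccc43)c(-c3cc(O)nc4ccccc34)c12` changes the group on that same aromatic carbon: 2-hydroxyquinolin-4-yl in place of 2-aminophenyl on an aromatic carbon. Among the measured compounds shown here, two measured steps bear on this place. Adding amino there gave an at least 16-fold lower number from compound 2 to compound 3 (1.22 log units; beyond the scatter), and removing nitro gave an at least 6.0-fold higher number from compound 1 to compound 2 (0.78 log units; beyond the scatter), so a substituent carrying a hydrogen-bond donor or acceptor at this position goes with lower numbers. The entering 2-hydroxyquinolin-4-yl keeps one donor and two acceptors, so compound 4 is expected to stay near compound 3, with a step of about a 1.3-fold higher number from compound 3 to compound 4 (0.10 log units; within the scatter). The estimate for compound 4 is 6000 nM, between 1500 nM and 30000 nM.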

Compound 4, half-maximal inhibitory concentration: 4630 nM
Compound 4: middle estimate off by 1.3-fold (0.11 log units), on the high side; low and high end bracket the measured number.
By their numbers in this assay, from the lowest: compounds 4 and 3 (each within the scatter of the next); then compound 1. At a limit, above all of these: compound 2.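

The position takes the larger 2-hydroxyquinolin-4-yl, with 11 heavy atoms, as well as the 7-atom 2-aminophenyl: a 1.0-fold lower number from compound 3 to compound 4 (0.01 log units; within the scatter). Set against the plain phenyl, the change is large, an at least 17-fold lower number from compound 2 to compound 4 (1.23 log units; beyond the scatter), and against 3-nitrophenyl it is modest, a 2.9-fold lower number from compound 1 to compound 4 (0.45 log units; beyond the scatter). The value of compound 2 is a limit of the assay, not a true number: the limit of > 80000 nM in this assay, at which 1 of the 4 values shown sits.

The compounds shown leave open whether the hydroxyl of the 2-hydroxyquinolin-4-yl matters at all. A plain quinolin-4-yl, or a methoxy in place of that hydroxyl, would address this.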